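The compounds below may be only part of what the source reports. "The series", "measured", "known", "first", "only" and "open" are said of these compounds alone.

Measured compounds:
compound 1, `CCOCC(COCC)Nc1nc(C)nc2c(-c3ccc(Cl)cc3Cl)c(C)nn12`, 6.2 nM;
compound 2, `CCCCC(CC)Nc1nc(C)nc2c(-c3ccc(Cl)cc3Cl)c(C)nn12`, 1.6 nM.

Both values come from an assay on isolated protein for displacement of a labelled ligand from corticotropin-releasing factor receptor 1 (Homo sapiens); a higher number here means a weaker inhibitor, a lower number a stronger inhibitor. Within the data shown here, compound 2 stands with the lower of the two numbers; its only neighbour, compound 1, is separated from it by a 3.9-fold lower number from compound 1 to compound 2 (0.59 log units; beyond the scatter), a step that exchanges an ether-bearing side chain for a plain alkyl one.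

Compound 3, `CCC(COC)Nc1nc(C)nc2c(-c3ccc(Cl)cc3Cl)c(C)nn12`, has not yet been measured in this assay. It differs from compound 2 by methoxy in place of propyl on a saturated chain carbon, two bonds along the chain from a nitrogen on an aromatic ring. Among the measured compounds shown here, the one measured step that bears on this, a 3.9-fold lower number from compound 1 to compound 2 (0.59 log units; beyond the scatter), went in favour of the alkyl chain when an ether-bearing chain was replaced. Compound 3 moves part of the way back toward compound 1, so a moderate rise in the number is expected, estimated as a 2.5-fold higher number from compound 2 to compound 3 (0.40 log units; beyond the scatter). Compound 3 is accordingly expected to give about 4 nM, within a range of 1.5 nM to 12 nM.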

Compound 3, inhibition constant: 1.9 nM
Estimate against measurement, compound 3: 2.1-fold (0.32 log units) above, within the range that was stated.
By their numbers in this assay, from the lowest: compounds 2 and 3 (each within the scatter of the next); then compound 1.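

In this assay the step of a 1.2-fold higher number from compound 2 to compound 3 (0.07 log units; within the scatter) shows that, on this saturated chain carbon, two bonds along the chain from a nitrogen on an aromatic ring, methoxy can stand in place of propyl without a difference the assay can resolve. An ether-bearing side chain is therefore not tied in itself to a higher number, since compound 3 carries one and goes against that reading, while a 3.3-fold lower number from compound 1 to compound 3 (0.51 log units; beyond the scatter) separates two chains that both contain ether oxygen. Nothing available explains this difference between the two ether-bearing chains.

On these data alone, it remains open whether a hydroxyl group or an amine would be tolerated in place of methoxy at this carbon. As far as these compounds go, it is also open whether a longer chain such as ethoxymethyl on this carbon would keep the number of compound 3 or approach that of compound 1.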